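This account rests on a few compounds, and the source may have more. Where it says the series, first, only, none or still open, it means among the compounds named here.

Measured compounds:
compound 1 `CCCNc1nc(-c2ccccc2)nc2c1nnn2Cc1ccccc1`, 37 nM
compound 2 `CCCNc1nc(-c2ccccc2)nc2c1nnn2Cc1ccccc1F`, 3.2 nM

In an assay on Cerebral cortex for displacement of a labelled ligand from adenosine receptor A1 (Bos taurus) (a higher number here means a weaker inhibitor, a lower number a stronger inhibitor), compound 2 gives the lowest of the two numbers; its nearest neighbour is compound 1, and the step of a 12-fold lower number from compound 1 to compound 2 (1.06 log units; beyond the scatter) lies beyond the scatter. Compound 3 `CCCCCCNc1nc(-c2ccccc2)nc2c1nnn2Cc1ccccc1F` differs from compound 2 by propyl in place of hydrogen on a saturated chain carbon, three bonds along the chain from a nitrogen on an aromatic ring. Going by the values given here, no measured step concerns this kind of change; the single known step, a fluoro for hydrogen exchange, does not bear on it. The expectation for compound 3 is therefore a small step of a 2.5-fold higher number from compound 2 to compound 3 (0.40 log units; beyond the scatter) in this assay, probably towards a higher number but possibly within the scatter. Compound 3 is estimated at 8 nM, range 2 nM to 40 nM.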

Compound 3, inhibition constant: 25 nM
For compound 3 the middle estimate is 3.1-fold (0.49 log units) below the measured one; the measured number falls inside the stated range.
By their numbers in this assay, from the lowest: compound 2; then compounds 3 and 1 (each within the scatter of the next).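

In this assay, propyl in place of hydrogen on a saturated chain carbon, three bonds along the chain from a nitrogen on an aromatic ring, gives a 7.8-fold higher number from compound 2 to compound 3 (0.89 log units; beyond the scatter). This position is therefore sensitive to the change from propyl to hexyl, which earlier compounds could not show, since they differ only by fluoro. No available evidence accounts for this step. With only propyl and hexyl shown, it remains open how the number moves with a butyl, a pentyl or a longer chain. Also open, as far as these compounds go, are a chain ending in an amine or a carboxylic acid, and whether the step holds without the fluoro.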